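A few compounds are considered here, and "the series" means these few. Any claim that something is new, unique, unknown or untested is made for them only; others in the source may bear on it.

Measured so far:
compound 1 `CC1=C(C(=O)OC2CCCCC2)C(c2ccco2)NC(=O)N1`: 1%
compound 2 `CC1=C(C(=O)OC2CCCC2)C(c2cccs2)NC(=O)N1`: 1%

Both compounds were tested in an assay on membranes from HEK293 cells for displacement of a labelled ligand from adenosine receptor A2b (Homo sapiens), read by scintillation counting, with a stated time of 30 min, tested at 1 uM; on this read-out lower numbers stand for less inhibition and higher numbers for more inhibition at the one concentration tested (going by the name of the read-out). Compound 1 gives 1% and compound 2 gives 1% in this assay, so compound 2 stands level with compound 1 at the digits reported; the two values lie within the scatter of each other, and nothing separates them. Among the compounds with values here, compound 1 and compound 2 differ from each other in more than one place, so no single step between them is counted.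

Compound 3 `CC1=C(C(=O)OC2CCCCC2)C(c2cccs2)NC(=O)N1` has not yet been measured. It differs from compound 2 by cyclohexyl in place of cyclopentyl on an oxygen next to a carbonyl group. Within the data shown here, only two values are known, both at the low end of the scale, and no counted step exists to guide the expectation. Compound 3 is therefore expected to stay where compound 2 stands, with a number 1 percentage points higher from compound 2 to compound 3 (within the scatter) amounting to no change beyond the scatter. The estimate for compound 3 in this assay is 2%, within a range from -8% to 12%.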

Compound 3, a percentage reported as inhibition, at one concentration (the size of the read-out at that concentration, not a potency): 3%
The estimate for compound 3 lay 1 percentage points below the measured number; the measured number falls inside the stated range.
By their numbers in this assay, from the lowest: compounds 1, 2 and 3 (each within the scatter of the next).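

Cyclohexyl in place of cyclopentyl on an oxygen next to a carbonyl group comes with a number 2 percentage points higher from compound 2 to compound 3 (within the scatter) in this assay and so gives the first counted reading at this place: the ring of carbon can take either size with no shift beyond the scatter. Thiophen-2-yl in place of furan-2-yl on a saturated ring carbon comes with a number 2 percentage points higher from compound 1 to compound 3 (within the scatter) and so shows the same absence of a shift at a second place on the shared core. Nothing measured here offers an explanation for these readings.

All three compounds sit at the low end of the scale, so neither step shows what would raise the number. As far as these compounds go, whether an amine or a carboxylic acid on that oxygen, or a longer chain in place of the methyl on the core, would change the reading remains open.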